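A few compounds are considered here, and "the series" means these few. Any claim that something is new, unique, unknown or untested is made for them only; others in the source may bear on it.

In a functional assay on SiHa cells (Homo sapiens) for cytotoxicity, read by MTT assay, with a stated time of 48 h (a lower number here means a stronger inhibitor, a higher number a weaker inhibitor), compound 2 `CCCCCCCCCCCCCCCCCCNC(=O)[C@@H](NS(=O)(=O)c1ccc(C)cc1)[C@@H](C)O` gives 29800 nM. Within the data shown here, its only measured neighbour, compound 1 `CCCCCCCCCCCCCCCCCCNC(=O)[C@@H](NC(=O)c1cc2ccccc2[nH]1)[C@@H](C)O`, gives 29600 nM in this assay, and the two numbers sit within the scatter of each other, so neither compound can be called the weaker. Among the measured compounds shown here, the single measured step, a 1.0-fold higher number from compound 1 to compound 2 (0.00 log units; within the scatter), is flat. Compound 3 `CCCCCCCCCCCCCCCCCCNC(=O)[C@@H](NS(=O)(=O)c1ccc2ccccc2c1)[C@@H](C)O` differs from compound 2 by naphthalen-2-yl in place of 4-methylphenyl on a sulfonyl sulfur. For the measured compounds named here, no measured step touches the group on the sulfonyl sulfur; the step from compound 1 to compound 2 exchanged the whole group on the amine nitrogen and left the number unchanged, which is the only guide available and it points to a series that has so far been insensitive to what is attached at that end of the shared core. On that basis compound 3 is expected to stay close to compound 2, with a step of a 1.2-fold lower number from compound 2 to compound 3 (0.08 log units; within the scatter) that is not expected to go beyond the scatter. The estimate for compound 3 in this assay is 25000 nM, with a range from 10000 nM to 60000 nM.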

Compound 3, half-maximal inhibitory concentration: 19900 nM
Beside the measured number, compound 3's estimate is 1.3-fold (0.10 log units) above it; the range from low to high includes it.
By their numbers in this assay, from the lowest: compounds 3, 1 and 2 (each within the scatter of the next).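

In this assay, among these compounds, naphthalen-2-yl in place of 4-methylphenyl on a sulfonyl sulfur gives a 1.5-fold lower number from compound 2 to compound 3 (0.18 log units; within the scatter), the first measured step at this position, and it lies within the scatter, as did the exchange on the amine nitrogen, a 1.0-fold higher number from compound 1 to compound 2 (0.00 log units; within the scatter). Going from one six-membered aromatic ring of carbon only to 2 such rings, with 10 heavy atoms entering where 7 leave, thus produces no readable difference, so this position has so far shown no more response than the amine nitrogen. Nothing available offers an explanation for this flat result.

The compounds shown carry only carbon aryl groups on the sulfonyl sulfur, so it remains open whether a group such as a carboxylic acid or an amine on that aryl ring would move the number beyond the scatter. Because all three compounds share the same long chain, they also leave open whether a shorter chain in its place would change the number in this assay, and whether such a change would alter the response to the group on the sulfonyl sulfur.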